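The source may hold more compounds than are shown below. What is called first, only, known or untested is meant among the compounds shown, and "the series" means these compounds.

Measured compounds:
Compound 1, `CCCn1c(=O)[nH]c2nc(-c3ccc(S(=O)(=O)N(C)C)cc3)[nH]c2c1=O`: 1220 nM
Compound 2, `CCCn1c(=O)[nH]c2nc(-c3ccc(S(=O)(=O)N4CCN(c5ccccc5Br)CC4)cc3)[nH]c2c1=O`: > 1000 nM
Compound 3, `CCCn1c(=O)c2[nH]c(-c3ccc(S(=O)(=O)N4CCN(c5ccc(Cl)cc5)CC4)cc3)nc2n(CC)c1=O`: > 1000 nM

Three compounds built on the shared core of compound 1 have been tested in an assay on CHO cells for displacement of a labelled ligand from adenosine receptor A3 (Homo sapiens), read by scintillation counting, with a stated time of 45 min, in the presence of a further agent that is not named here; on this read-out higher numbers stand for weaker inhibition and lower numbers for stronger inhibition. Compound 1 gives 1220 nM in this assay. For compound 2 the read-out is only a limit of the assay, > 1000 nM, and not a number. Compound 3 likewise reaches only a limit, > 1000 nM. Thus compound 2 stands at the weak end of what is shown, on the same footing as compound 3, and no value among the three is separated from the others beyond the usual scatter. Within the data shown here, two of the three values sit at the limit of > 1000 nM in this assay, at which 2 of the 3 values shown sit, so the set gives no measured step from which a trend can be read.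

The next compound, compound 4, `CCCn1c(=O)[nH]c2nc(-c3ccc(S(=O)(=O)N4CCN(c5ccccc5)CC4)cc3)[nH]c2c1=O`, differs from compound 2 by hydrogen in place of bromo on an aromatic carbon. Among the measured compounds shown here, no step between measured compounds is recorded for this change. The step is therefore expected to be a step that the limit leaves unreadable from compound 2 to compound 4, not beyond the scatter and with no clear direction. Compound 4 is estimated at 2000 nM, within a range from 800 nM to 6000 nM, with a fair chance that this assay again reports only a limit.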

Compound 4, inhibition constant: > 1000 nM
Compound 4 gave a limit, no number; the forecaster's own chance of this, stated with the estimate: 60%; the middle value lies beyond the limit too.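

Compound 4 gives only a limit in this assay, > 1000 nM, and not a number. No step from compound 2 to compound 4 can be read, because both compounds stand at a limit: the limit of > 1000 nM in this assay, at which 3 of the 4 values shown sit.

The compounds shown leave open whether hydrogen in place of bromo on an aromatic carbon shifts the read-out in either direction.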